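Working notes: amide replaces aminomethyl on the aryl piperidine

The source may hold more compounds than are shown below. What is called first, only, known or untested is meant among the compounds shown, and "the series" means these compounds.

Three compounds built on one shared core have been run in a functional assay on cells for agonist activity at Free fatty acid receptor 1 (Homo sapiens), read by FLIPR and calcium flux, with a stated time of 60 min (a higher number here means a larger maximal response, a lower number a smaller maximal response), so far. Compound 1 `COc1ccc(CCCC(C)(C)C)c(N2CCC(COc3cccc(C(CC(=O)O)C4CC4)c3)CC2)c1` gives 106% in that run. Compound 2 `COc1ccc(F)c(N2CCC(COc3cccc(C(CC(=O)O)C4CC4)c3)CC2)c1` gives 114% and compound 3 `COc1ccc(CN(C)CC(C)C)c(N2CCC(COc3cccc(C(CC(=O)O)C4CC4)c3)CC2)c1` gives 110% in the same run. Every step among them sits inside the scatter: a number 8 percentage points higher from compound 1 to compound 2 (within the scatter), a number 4 percentage points higher from compound 1 to compound 3 (within the scatter) and a number 4 percentage points lower from compound 2 to compound 3 (within the scatter). Compound 3 therefore stands second highest of the three numbers, with compound 1 nearest and compound 2 furthest, yet none of the three can be told apart from the others.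

Compound 4 `COc1ccc(C(=O)N(C)CC(C)(C)C)c(N2CCC(COc3cccc(C(CC(=O)O)C4CC4)c3)CC2)c1` differs from compound 3 in one place: methyl(neopentyl)carbamoyl in place of (isobutyl(methyl)amino)methyl on an aromatic carbon. Among the compounds with values here, the steps that bear on this change are a number 4 percentage points lower from compound 2 to compound 3 (within the scatter) and a number 8 percentage points higher from compound 1 to compound 2 (within the scatter), both within the scatter, which together show that fluoro, 4,4-dimethylpentyl and (isobutyl(methyl)amino)methyl on that aromatic carbon all leave the maximal response where it was. Nothing in these three compounds sets methyl(neopentyl)carbamoyl apart from those groups, so the expected step is none beyond the scatter, no change at the digits printed from compound 3 to compound 4 (within the scatter). Compound 4 is estimated at 110%, with a range from 98% to 122%.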

Compound 4, largest response reached (Emax), in percent of the reference or control that the assay uses: 107%
Estimate against measurement, compound 4: 3 percentage points above; low and high end bracket the measured number.
By their numbers in this assay, from the lowest: compounds 1, 4, 3 and 2 (each within the scatter of the next).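

In this assay, within the data shown here, the aromatic carbon para to a methoxy group now also accepts methyl(neopentyl)carbamoyl, the only group of the four with a double bond outside aromatic rings, and the step is a number 3 percentage points lower from compound 3 to compound 4 (within the scatter). Against the two other groups on that carbon the picture is the same, with a number 7 percentage points lower from compound 2 to compound 4 (within the scatter) and a number 1 percentage points higher from compound 1 to compound 4 (within the scatter). The maximal response therefore does not separate this amide from the amine-bearing side chain, from fluoro or from 4,4-dimethylpentyl, and no measurement at hand bears on why this carbon tolerates all four groups.

Open, as far as these compounds go, is whether any group on this carbon moves the maximal response beyond the scatter: a carboxylic acid, a primary amine or a secondary amide that keeps the amide hydrogen could test this, as could plain hydrogen in place of these groups. A maximal response also says nothing about the concentration at which each compound reaches it, so compounds that cannot be told apart here may still differ in potency.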